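A few compounds are considered here, and "the series" means these few. Any claim that something is new, unique, unknown or untested is made for them only; others in the source may bear on it.

Within the data shown here, compound 1 `COc1cc(OC)c(Cl)c(-c2ccc3c(NC(=O)c4ccc(C5CCN(C)CC5)cc4)n[nH]c3n2)c1Cl` is one of two compounds measured in a functional assay on NCI-H1581 cells (Homo sapiens) for antiproliferative activity, read by CCK-8 assay, with a stated time of 72 h; on this read-out lower numbers stand for stronger inhibition and higher numbers for weaker inhibition. Compound 1 gives 8.2 nM, the higher of the two numbers, and compound 2 `COc1cc(OC)c(Cl)c(-c2ccc3c(NC(=O)c4ccc(N5CCN(C)CC5)cn4)n[nH]c3n2)c1Cl` gives 4.4 nM. The two values sit within the scatter of each other, so nothing separates them. Compound 3 `COc1cc(OC)c(Cl)c(-c2ccc3c(NC(=O)c4ccc(N(C)C)cc4)n[nH]c3n2)c1Cl` has not yet been measured. It differs from compound 1 in one place: dimethylamino in place of 1-methylpiperidin-4-yl on an aromatic carbon. Among the measured compounds shown here, no step between measured compounds is known. The change is expected to give no step beyond the scatter, with the expected step being a 1.5-fold higher number from compound 1 to compound 3 (0.17 log units; within the scatter). Compound 3 is estimated at 12 nM, with a range from 4 nM to 40 nM.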

Compound 3, half-maximal inhibitory concentration: 294 nM
The estimate for compound 3 lay 25-fold (1.39 log units) below the measured number; measured number outside the range, above it.
By their numbers in this assay, from the lowest: compounds 2 and 1 (each within the scatter of the next); then compound 3.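

On this aromatic carbon, para to a large group, the substituent matters strongly: replacing 1-methylpiperidin-4-yl with dimethylamino gives a 36-fold higher number from compound 1 to compound 3 (1.55 log units; beyond the scatter). The change removes the six-membered non-aromatic ring and leaves 3 heavy atoms where there were 7, while the count of hydrogen-bond acceptors stays the same. No measurement at hand accounts for this loss. The compounds shown leave open whether the ring itself or simply the larger group is what counts. A morpholine ring or an open 2-(dimethylamino)ethoxy chain at this position would help to separate the two.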